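Ring Size at the Chain Amine: Pyrrolidine to Piperidine

This account rests on a few compounds, and the source may have more. Where it says the series, first, only, none or still open, it means among the compounds named here.

Two measured compounds share one core and differ only in the amine at the end of a short chain. Compound 1 `CN(C)CCn1c(=O)sc2cc(S(=O)(=O)N(C)c3ccccc3)ccc21` carries dimethylamino there; in an assay on HEK293 cells for displacement of a labelled ligand from 5-hydroxytryptamine receptor 6 (Homo sapiens), read by radioligand binding, with a stated time of 60 min, tested at 100 nM (on this read-out lower numbers stand for less inhibition and higher numbers for more inhibition at the one concentration tested (going by the name of the read-out)), compound 1 gives 5%. Compound 2 `CN(c1ccccc1)S(=O)(=O)c1ccc2c(c1)sc(=O)n2CCN1CCCC1` carries pyrrolidin-1-yl instead, and in this assay compound 2 gives 10%. The step of a number 5 percentage points higher from compound 1 to compound 2 (within the scatter) shows that these two numbers cannot be told apart. Compound 2 holds the higher of the two numbers, but the gap to compound 1 lies within the scatter, so neither stands out.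

Compound 3 `CN(c1ccccc1)S(=O)(=O)c1ccc2c(c1)sc(=O)n2CCN1CCCCC1` has not yet been measured. It differs from compound 2 in one place: piperidin-1-yl in place of pyrrolidin-1-yl on a saturated chain carbon, two bonds along the chain from an aromatic nitrogen. For the measured compounds named here, the only step that bears on this change also swapped the amine at this place, and it was a number 5 percentage points higher from compound 1 to compound 2 (within the scatter), a small move. Going by the values given here, with both measured numbers low and the one relevant step within the scatter, the expected step of no change at the digits printed from compound 2 to compound 3 (within the scatter) is none beyond the scatter. Compound 3 is therefore estimated at 10%, with a range from 0% to 25%.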

Compound 3, a percentage reported as inhibition, at one concentration (the size of the read-out at that concentration, not a potency): 0%
For compound 3 the middle estimate is 10 percentage points above the measured one, and the stated range covers the measured number.
By their numbers in this assay, from the lowest: compounds 3, 1 and 2 (each within the scatter of the next).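

Going from the five-membered to the six-membered ring at this place, on a saturated chain carbon two bonds along the chain from an aromatic nitrogen, gives in this assay a result that reads a number 10 percentage points lower from compound 2 to compound 3 (within the scatter) and so cannot be told apart from no change. Set against the open-chain dimethylamino group, piperidin-1-yl reads a number 5 percentage points lower from compound 1 to compound 3 (within the scatter) and is likewise indistinguishable, so dimethylamino, pyrrolidin-1-yl and piperidin-1-yl now all sit within the scatter of one another at the single concentration tested. Nothing available here offers an explanation for these numbers.

Because this read-out reports one concentration only, the compounds shown leave open whether these three amines would separate at a higher concentration. They also leave open whether a different amine at the same place, such as morpholin-4-yl or 4-methylpiperazin-1-yl, or a longer chain such as 3-(piperidin-1-yl)propyl in place of 2-(piperidin-1-yl)ethyl, would give a step beyond the scatter.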